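A few compounds are considered here, and "the series" means these few. Any claim that something is new, unique, unknown or untested is made for them only; others in the source may bear on it.

In a functional assay on HL-60 cells (Homo sapiens) for cytotoxicity, read by luminescence and CellTiter-Glo, with a stated time of 3 days (a higher number here means a weaker inhibitor, a lower number a stronger inhibitor), compound 1 (`O=C(Nc1cc(C(F)(F)F)cc(C(F)(F)F)c1)c1ccc(-c2ccccc2)cc1O`) gives 1140 nM and compound 2 (`N#Cc1ccc(NC(=O)c2ccc3cccnc3c2O)c(F)c1`) gives 730 nM here, two values within the scatter of each other. Compound 3 (`COc1ccc(C(=O)Nc2ccc(C#N)cc2)c(O)c1`) gives 5470 nM in the same read-out, a higher number than compound 2 by more than the scatter. Compound 4 (`N#Cc1ccc(NC(=O)c2ccc3cccnc3c2O)c(C#N)c1`) carries one change from compound 2: cyano in place of fluoro on an aromatic carbon, ortho to a large group and meta to a cyano group (cyano in place of fluoro on an aromatic carbon). Going by the values given here, no pair measured so far differs in one place only, so nothing in the data sets the size of this step. In this assay a step within the scatter is expected, with no firm direction. The estimate amounts to a 1.1-fold higher number from compound 2 to compound 4 (0.04 log units; within the scatter) as an expected step. For compound 4 the expected value is 800 nM (estimated range 270 nM to 2400 nM).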

Compound 4, half-maximal inhibitory concentration: 890 nM
Compound 4: the middle estimate sits 1.1-fold (0.05 log units) below what was measured; the range from low to high includes it.
By their numbers in this assay, from the lowest: compounds 2, 4 and 1 (each within the scatter of the next); then compound 3.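

In this assay, cyano in place of fluoro on this aromatic carbon, ortho to a large group and meta to a cyano group, gives a 1.2-fold higher number from compound 2 to compound 4 (0.09 log units; within the scatter), the first single-place step available in the series. At this position, the two-heavy-atom cyano group and the one-heavy-atom fluoro group therefore cannot be told apart in this read-out. Nothing available accounts for this result. As far as these compounds go, only these two groups are seen here, so an amine or a carboxylic acid at this position remains open. From the compounds shown here alone, whether the same step holds on the core of compound 1 or compound 3 also remains open.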